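Shortening an Ether Chain Toward a Plain Methoxy Group

The compounds below may be only part of what the source reports. "The series", "measured", "known", "first", "only" and "open" are said of these compounds alone.

Compound 1 `CC(C)CCOc1cccc2occ(Cc3coc4ccccc4c3=O)c(=O)c12` carries an isopentyloxy group on one ring of the shared core. In a functional assay on PC-3 cells (Homo sapiens) for antiproliferative activity, read by XTT assay (on this read-out lower numbers stand for stronger inhibition and higher numbers for weaker inhibition), compound 1 reaches only the limit of the measurement, > 10000 nM, so no number is known for it. Compound 1 therefore sits at the limit of > 10000 nM in this assay, at which 1 of the 2 values shown sits. Going by the values given here, the other measured compound, compound 2 `COc1ccc2c(=O)c(Cc3coc4cccc(OCC5CCCCC5)c4c3=O)coc2c1`, differs from compound 1 in more than one place and gives no single step; in this assay compound 2 gives 1120 nM.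

Compound 3 `COc1cccc2occ(Cc3coc4ccccc4c3=O)c(=O)c12` has not yet been measured. It differs from compound 1 by hydrogen in place of isobutyl on a saturated chain carbon bound to an oxygen on an aromatic ring. Because compound 1 stands only at the limit of > 10000 nM in this assay, at which 1 of the 2 values shown sits, the size of this step cannot be read from any measured pair. Among the compounds with values here, the only guide is that compound 2, which also carries a methoxy group, gives a number, 1120 nM, rather than a limit. A small gain is expected, leaving compound 3 near the limit, so compound 3 is estimated at 9000 nM, between 2000 nM and 40000 nM. The expected step is then an at least 1.1-fold lower number from compound 1 to compound 3 (0.04 log units; that floor lies within the scatter).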

Compound 3, half-maximal inhibitory concentration: 3490 nM
Compound 3: middle estimate off by 2.6-fold (0.41 log units), on the high side; the range from low to high includes it.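

Going from isopentyloxy to methoxy at this position gives the first step here that can be read, even though one end of it is not a number: in this assay the change gives an at least 2.8-fold lower number from compound 1 to compound 3 (0.45 log units; beyond the scatter). Before this result, nothing showed whether replacing the isobutyl part with hydrogen moved the read-out at all; now the smaller ether is seen to go with stronger inhibition, by more than the usual scatter. The step is only a floor, and its full size stays unknown, as compound 1 has a limit rather than a number: the limit of > 10000 nM in this assay, at which 1 of the 3 values shown sits.

Going by these compounds, whether an ethoxy group or a free hydroxyl group at this position would lower the number further remains open. Compound 2 differs in more than one place, so it cannot show whether the same shortening would help elsewhere on the shared core.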